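From Trifluoromethyl to Ethoxy on a Shared Core

The source may hold more compounds than are shown below. What is called first, only, known or untested is meant among the compounds shown, and "the series" means these compounds.

Of the compounds shown here, three built on one shared core have been tested in a functional assay on HeLa cells (Homo sapiens) for inhibition, read by sulforhodamine B assay; on this read-out lower numbers stand for stronger inhibition and higher numbers for weaker inhibition. Compound 1 `COc1cccc(NC2=CC(=O)c3nc4n(c3C2=O)[C@H]2OC[C@@H](O)[C@H]2OC4)c1` carries a 3-methoxyphenyl on the amine nitrogen, and in this assay compound 1 gives 4280 nM. Compound 2 `O=C1C=C(Nc2ccccc2)C(=O)c2c1nc1n2[C@H]2OC[C@@H](O)[C@H]2OC1` carries a plain phenyl there, and in this assay compound 2 gives 5620 nM. Compound 3 `O=C1C=C(Nc2ccc(C(F)(F)F)cc2)C(=O)c2c1nc1n2[C@H]2OC[C@@H](O)[C@H]2OC1` carries a 4-(trifluoromethyl)phenyl. For compound 3 this assay reports only a limit, > 8000 nM, not a number. Because of the limit of > 8000 nM in this assay, at which 1 of the 3 values shown sits, compound 3 stands at the weak edge of what has been seen, without a precise value.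

Compound 4 `CCOc1ccc(NC2=CC(=O)c3nc4n(c3C2=O)[C@H]2OC[C@@H](O)[C@H]2OC4)cc1` is the next step from compound 3: ethoxy in place of trifluoromethyl on an aromatic carbon. For the measured compounds named here, two measured steps bear on this. The step of an at least 1.4-fold higher number from compound 2 to compound 3 (0.15 log units; that floor lies within the scatter) shows that adding trifluoromethyl cost a little, and the step of a 1.3-fold higher number from compound 1 to compound 2 (0.12 log units; within the scatter) shows that removing methoxy cost a little as well, both within the scatter. Ethoxy, like the methoxy of compound 1, is an oxygen-linked group, so the expected step is a modest gain, an at least 1.6-fold lower number from compound 3 to compound 4 (0.20 log units; that floor lies within the scatter). Compound 4 is therefore estimated at 5000 nM. The expected range for compound 4 runs from 2500 nM to 10000 nM.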

Compound 4, half-maximal inhibitory concentration: 3110 nM
Compound 4: the middle estimate sits 1.6-fold (0.21 log units) above what was measured, and the stated range covers the measured number.
By their numbers in this assay, from the lowest: compounds 4, 1 and 2 (each within the scatter of the next). At a limit, above all of these: compound 3.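

Replacing trifluoromethyl with ethoxy at this position produces the first step among these compounds that is printed as beyond the scatter (an at least 2.5-fold lower number from compound 3 to compound 4 (0.41 log units; beyond the scatter)). The ethoxy group does not set compound 4 apart from the other two measured compounds, since both (a 1.8-fold lower number from compound 2 to compound 4 (0.26 log units; within the scatter)) and (a 1.4-fold lower number from compound 1 to compound 4 (0.14 log units; within the scatter)) stay within the scatter, so in this assay the clear separation here is between ethoxy and trifluoromethyl, not between ethoxy and hydrogen or the 3-methoxyphenyl of compound 1. Going by these compounds, the true size of the step from trifluoromethyl to ethoxy remains unknown, as compound 3 is held at a limit, not a number: the limit of > 8000 nM in this assay, at which 1 of the 4 values shown sits.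

On these data alone, how an amine, a carboxylic acid or a longer chain would fare at this position stays open, and these compounds give no reading for any of them. Compounds 1 and 4 also differ both in the oxygen-linked group and in where it sits on the phenyl ring, so the effects of those two changes cannot be told apart here.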